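Five-membered ring variation on the salicylic acid-type series

A few compounds are considered here, and "the series" means these few. Any claim that something is new, unique, unknown or untested is made for them only; others in the source may bear on it.

Measured compounds:
- compound 1 `O=C(O)c1cc(-c2csnn2)ccc1O`: > 200 mg/kg
- compound 2 `O=C(O)c1cc(-n2ccnc2)ccc1O`: 75 mg/kg
- compound 3 `O=C(O)c1cc(-c2cccs2)ccc1O`: 60 mg/kg

In a functional assay on the whole organism for inhibition, with Rattus norvegicus as the target, read by paw edema (a higher number here means that more compound is needed for the effect, a lower number that less compound is needed), compound 1 reaches only the assay limit, > 200 mg/kg, and gives no number. In this assay compound 2 gives 75 mg/kg, the higher of the two numbers recorded, while compound 3 gives 60 mg/kg; the step of a 1.3-fold lower number from compound 2 to compound 3 (0.10 log units; within the scatter) lies within the scatter, so the two are not separated. The steps of an at least 2.6-fold lower number from compound 1 to compound 2 (0.42 log units; beyond the scatter) and an at least 3.3-fold lower number from compound 1 to compound 3 (0.52 log units; beyond the scatter) are both beyond the scatter.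

Compound 4 `O=C(O)c1cc(-c2ccns2)ccc1O` is not yet measured. Its change from compound 2 is 1,2-thiazol-5-yl in place of 1H-imidazol-1-yl on an aromatic carbon. The closest measured step, a 1.3-fold lower number from compound 2 to compound 3 (0.10 log units; within the scatter), exchanged the same 1H-imidazol-1-yl for another five-membered ring and stayed within the scatter; the limit of > 200 mg/kg in this assay, at which 1 of the 3 values shown sits, for compound 1 shows that not every five-membered ring keeps the effect. The expected step of a 1.2-fold higher number from compound 2 to compound 4 (0.08 log units; within the scatter) is therefore small, with a broad range. Compound 4 is estimated at 90 mg/kg, between 40 mg/kg and 200 mg/kg.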

Compound 4, dose for half-maximal effect in the Rattus norvegicus assay: 80 mg/kg
The estimate for compound 4 lay 1.1-fold (0.05 log units) above the measured number; measured number inside the range.
By their numbers in the Rattus norvegicus assay, from the lowest: compounds 3, 2 and 4 (each within the scatter of the next). At a limit, above all of these: compound 1.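

In the Rattus norvegicus assay, 1,2-thiazol-5-yl at this position, para to a hydroxy group, joins the two earlier rings without separation, with the steps of a 1.1-fold higher number from compound 2 to compound 4 (0.03 log units; within the scatter) and a 1.3-fold higher number from compound 3 to compound 4 (0.12 log units; within the scatter). Also in the Rattus norvegicus assay, compound 1 stays at a limit of the assay, and the step of an at least 2.5-fold lower number from compound 1 to compound 4 (0.39 log units; beyond the scatter) shows that a ring sulfur alone does not decide the outcome, since compound 4 and compound 1 both carry one. The exchange that leaves that read-out unseparated does separate the pair on another: in a physicochemical assay for solubility, in phosphate buffer, at pH 7 (on this read-out lower numbers stand for lower solubility and higher numbers for higher solubility), compound 2 gives 2000 ug/mL and compound 4 gives 7300 ug/mL, the step being a 3.7-fold higher number from compound 2 to compound 4 (0.56 log units; beyond the scatter).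

As far as these compounds go, only five-membered aromatic rings appear at this position, so whether an amine or a longer alkyl chain there keeps the effect stays open. From the compounds shown here alone, what sets compound 1 apart from compound 4 also stays open.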